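The source may hold more compounds than are shown below. What is called first, only, known or untested is meant among the compounds shown, and "the series" means these compounds.

Compounds measured in an assay on SK-BR-3 cells for inhibition of Aromatase (Homo sapiens); on this read-out lower numbers stand for stronger inhibition and higher numbers for weaker inhibition:
compound 1, `N#Cc1ccc(C(=O)Nc2ccc([N+](=O)[O-])cc2OCc2ccccc2)cc1`, > 25000 nM
compound 2, `O=[N+]([O-])c1ccc(S(=O)(=O)Nc2ccc([N+](=O)[O-])cc2OCc2ccccc2)cc1`, 2170 nM

Within the data shown here, of these two results, only the one for compound 2 is an actual number. The entry for compound 1 is a limit of this assay, not a measured concentration, as shown by the limit of > 25000 nM in this assay, at which 1 of the 2 values shown sits. Among the measured compounds shown here, compound 2 therefore stands as the single number available, and nothing beyond it can be ordered or compared in size.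

Compound 3, `Cc1ccc(S(=O)(=O)Nc2ccc([N+](=O)[O-])cc2OCc2ccccc2)cc1`, has not yet been tested. It differs from compound 2 in one place: methyl in place of nitro on an aromatic carbon, para to a large group, so that the 4-nitrophenyl of compound 2 becomes 4-methylphenyl. For the measured compounds named here, no measured pair here shows the effect of such an exchange, so the size of the step is open. For compound 3 a step from compound 2 of a 1.8-fold higher number from compound 2 to compound 3 (0.27 log units; within the scatter) is expected, slightly toward weaker inhibition and with wide uncertainty. Compound 3 is thus estimated at 4000 nM, between 1000 nM and 20000 nM.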

Compound 3, half-maximal inhibitory concentration: 17400 nM
Compound 3: the middle estimate sits 4.4-fold (0.64 log units) below what was measured; low and high end bracket the measured number.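

Among these compounds, the exchange of nitro for methyl on an aromatic carbon, para to a large group, is the first change here whose size can be read as a number: in this assay it gives a clear step (an 8.0-fold higher number from compound 2 to compound 3 (0.90 log units; beyond the scatter)) toward weaker inhibition. This position is therefore not indifferent to what it carries, and of the two groups compared, the 4-nitrophenyl of compound 2 goes with the stronger inhibition, by a margin beyond the usual scatter. Nitro and methyl differ at once in heavy atoms and in hydrogen-bond acceptors, so this single step cannot be assigned to either difference, and nothing measured here gives a reason for it.

As far as these compounds go, it remains open whether another group at this position, such as an amine, a carboxylic acid or a nitrile, would read like nitro or like methyl. Also open, from the compounds shown here alone, are how a longer chain in place of methyl would read and whether the same exchange would give a step of this size elsewhere on the shared core.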